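The source may report more compounds than this note shows. Statements on the series, on what has been measured and on what is new or still open speak of the compounds shown alone.

Of the compounds shown here, two have numbers so far. Compound 1 `CCN1CCN(CC(=O)Nc2nc3cc(OC)ccc3s2)CC1` in a functional assay on the whole organism (strain Wistar) for inhibition, with Rattus norvegicus as the target, read by paw edema, with a stated time of 2 h, at a dose of 30 mg/kg (a lower number here means less inhibition, a higher number more inhibition at the dose given (going by the name of the read-out)), gives 17.4%. Compound 2 `O=C(CN1CCN(c2ccccc2)CC1)Nc1nc2cc([N+](=O)[O-])ccc2s1` in this assay gives 34.8%, the higher of the two numbers, with the gap to compound 1 beyond the scatter. The two differ in more than one place, so what the gap belongs to cannot be told from these two values alone.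

Compound 3 `CCN1CCN(CC(=O)Nc2nc3cc([N+](=O)[O-])ccc3s2)CC1` is not yet measured. It keeps the core of compound 2 and changes only (ethyl in place of phenyl on an amine nitrogen in a ring). Compound 3 also shares its ethyl-bearing ring with compound 1, whose number in this assay is the lower one. A step downward from compound 2 is therefore expected, of modest size, possibly within the scatter: the expected step is a number 8.8 percentage points lower from compound 2 to compound 3 (within the scatter). For compound 3 in this assay the expected value is 26%, within 12% to 40%.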

Compound 3, a percentage reported as inhibition, in the whole organism at one dose (the size of the read-out at that dose, not a potency): 17.4%
For compound 3 the middle estimate is 8.6 percentage points above the measured one; low and high end bracket the measured number.
By their numbers in this assay, from the lowest: compounds 1 and 3 (each within the scatter of the next); then compound 2.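

In this assay the group on the amine nitrogen in a ring matters with nitro held on the shared core: ethyl in place of phenyl gives a number 17.4 percentage points lower from compound 2 to compound 3 (beyond the scatter) at this position. For the compounds shown here, with ethyl held, nitro in place of methoxy on an aromatic carbon gives no change at the digits printed from compound 1 to compound 3 (within the scatter) in this pair, so of the two single changes only the one on the ring nitrogen moves the number beyond the scatter. Nothing at hand gives a reason for either step.

From the compounds shown here alone, it remains open whether the step between phenyl and ethyl holds with methoxy in place of nitro on the core. Going by these compounds, it is also open whether a benzyl group, a longer alkyl chain or a plain hydrogen on that ring nitrogen would read like phenyl or like ethyl.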